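Nitro in Place of Methoxy: An Expected Loss

A few compounds are considered here, and "the series" means these few. Any claim that something is new, unique, unknown or untested is made for them only; others in the source may bear on it.

Of the compounds shown here, two have been measured in an assay on microsomes from liver for inhibition of 3-hydroxy-3-methylglutaryl-coenzyme A reductase (Sus scrofa), read by colorimetric assay; on this read-out higher numbers stand for weaker inhibition and lower numbers for stronger inhibition. Compound 1 `CC(C)=CCC/C(C)=C/CCC1=C[C@H](c2ccccc2[N+](=O)[O-])OC1=O` gives 18900 nM, and compound 2 `COc1ccc([C@H]2C=C(CC/C=C(\C)CCC=C(C)C)C(=O)O2)cc1` gives 6210 nM. Compound 2 therefore stands at the lower of the two numbers, and compound 1 sits a clear step higher, beyond the usual scatter. Compound 3 `CC(C)=CCC/C(C)=C/CCC1=C[C@H](c2ccc([N+](=O)[O-])cc2)OC1=O` differs from compound 2 by nitro in place of methoxy on an aromatic carbon. Because compound 1 gives 18900 nM while also carrying a nitro group on its aromatic ring, a moderate step upward in this assay is expected. Compound 3 is estimated at 12000 nM, within 4000 nM to 36000 nM. That corresponds to an expected step of a 1.9-fold higher number from compound 2 to compound 3 (0.29 log units; within the scatter).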

Compound 3, half-maximal inhibitory concentration: 7430 nM
Compound 3: the middle estimate sits 1.6-fold (0.21 log units) above what was measured; the measured number falls inside the stated range.
By their numbers in this assay, from the lowest: compounds 2 and 3 (each within the scatter of the next); then compound 1.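

In this assay, nitro in place of methoxy on an aromatic carbon, para to a large group, gives a 1.2-fold higher number from compound 2 to compound 3 (0.08 log units; within the scatter) and so the two groups cannot be told apart at this place. Compound 3 carries a nitro group as compound 1 does, yet compound 1 gives 18900 nM and compound 3 gives 7430 nM so a nitro group on the ring does not by itself go with the higher number. No evidence available here accounts for this result.

From the compounds shown here alone, whether an amine or a carboxylic acid at this place would stand apart from methoxy and nitro remains open.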